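The compounds below may be only part of what the source reports. "The series", "measured", "known", "first", "only" and "open" are said of these compounds alone.

- compound 1 `COc1cc(NCc2ccc(C)s2)ccc1-c1cnco1`: 34400 nM
- compound 2 `COc1cc(NCc2scnc2C)ccc1-c1cnco1`: 58500 nM
- compound 3 `COc1cc(NCc2ccc(Cl)s2)ccc1-c1cnco1`: 43200 nM

All three values come from an ADME assay on Huh-7 cells (Homo sapiens) for cytotoxicity, read by MTT assay, with a stated time of 96 h; on this read-out lower numbers stand for higher toxicity in this test and higher numbers for lower toxicity in this test. Compound 3 does not separate from the other two: the data show a 1.3-fold higher number from compound 1 to compound 3 (0.10 log units; within the scatter) and a 1.4-fold lower number from compound 2 to compound 3 (0.13 log units; within the scatter). Compound 4 `COc1cc(NCc2ccncc2)ccc1-c1cnco1` is not yet measured and differs from compound 3 in one place: pyridin-4-yl in place of 5-chlorothiophen-2-yl on a saturated chain carbon bound to a nitrogen on an aromatic ring. Pyridin-4-yl takes the place of 5-chlorothiophen-2-yl on a saturated chain carbon bound to a nitrogen on an aromatic ring. Two earlier swaps at this place bear on the change: a 1.7-fold higher number from compound 1 to compound 2 (0.23 log units; within the scatter) and a 1.4-fold lower number from compound 2 to compound 3 (0.13 log units; within the scatter). Going by the values given here, both are small, but no compound carrying pyridin-4-yl has been measured, so the expectation stays loose. Among the compounds with values here, the expected change is a 1.0-fold higher number from compound 3 to compound 4 (0.02 log units; within the scatter), with no step expected beyond the scatter. For compound 4 the estimated value is 45000 nM, with an expected range of 20000 nM to 100000 nM.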

Compound 4, half-maximal cytotoxic concentration: 72200 nM
Compound 4: middle estimate off by 1.6-fold (0.21 log units), on the low side; the range from low to high includes it.
By their numbers in this assay, from the lowest: compounds 1, 3, 2 and 4 (each within the scatter of the next, the first and the last beyond it).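

Pyridin-4-yl brings the first six-membered aromatic ring to this place, and in this assay two of its steps stay within the scatter: a 1.7-fold higher number from compound 3 to compound 4 (0.22 log units; within the scatter) and a 1.2-fold higher number from compound 2 to compound 4 (0.09 log units; within the scatter). Only a 2.1-fold higher number from compound 1 to compound 4 (0.32 log units; beyond the scatter) passes the scatter, and modestly, so ring size sets no clear pattern, with compound 2 and compound 3 going against one. Nothing measured here accounts for that single step. Still open, on these data alone, is how piperidin-4-yl, a saturated ring carrying an amine, or a carboxylic acid on the same saturated chain carbon would read in this assay.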